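Substituent swap on the aromatic ring: compound 2 to compound 3

This account rests on a few compounds, and the source may have more. Where it says the series, first, only, none or still open, it means among the compounds named here.

Measured so far in a functional assay for antagonist activity at melanin-concentrating hormone receptor 1 (Homo sapiens); on this read-out higher numbers stand for weaker inhibition and lower numbers for stronger inhibition:
- compound 1 `CCO/N=C/c1cccc([C@]23CCC(N(CCN(C(C)C)C(C)C)C(=O)Nc4ccc(F)c(Cl)c4)CC2C3)c1`, compound 1 gives 29 nM
- compound 2 `CC(C)N(CCN(C(=O)Nc1ccc(F)c(Cl)c1)C1CC[C@]2(c3cccc(CNS(C)(=O)=O)c3)CC2C1)C(C)C`, compound 2 gives 18 nM

Among the measured compounds shown here, compound 2 carries the lower of the two numbers, but the one step so far, a 1.6-fold lower number from compound 1 to compound 2 (0.21 log units; within the scatter), lies within the scatter, so no order between compound 1 and compound 2 can be read from it.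

Compound 3 `CC(C)N(CCN(C(=O)Nc1ccc(F)c(Cl)c1)C1CC[C@]2(c3cccc(CN4CC[C@H](O)C4)c3)CC2C1)C(C)C` differs from compound 2 in one place: 3-hydroxypyrrolidin-1-yl in place of methanesulfonamido on a saturated chain carbon bound to an aromatic carbon. For the measured compounds named here, no measured step covers this exchange; the only step available, from compound 1 to compound 2, concerns a different group at the same aromatic carbon and was itself within the scatter. On that basis the expected step of a 1.1-fold higher number from compound 2 to compound 3 (0.05 log units; within the scatter) is none beyond the scatter, in either direction. Compound 3 is therefore estimated at 20 nM in this assay, with a range from 6 nM to 70 nM.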

Compound 3, inhibition constant: 21 nM
For compound 3 the middle estimate is 1.1-fold (0.02 log units) below the measured one; the range from low to high includes it.
By their numbers in this assay, from the lowest: compounds 2, 3 and 1 (each within the scatter of the next).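

Exchanging methanesulfonamido for 3-hydroxypyrrolidin-1-yl on a saturated chain carbon bound to an aromatic carbon in this assay gives a 1.2-fold higher number from compound 2 to compound 3 (0.07 log units; within the scatter) and shows that a group with a five-membered non-aromatic ring can stand at this place with no step beyond the scatter. Set against the group of compound 1 on the same aromatic carbon, the new group gives a 1.4-fold lower number from compound 1 to compound 3 (0.14 log units; within the scatter) and leaves all three groups at this aromatic carbon indistinguishable on this read-out. Nothing at hand offers an explanation for this result.

Still open, as far as these compounds go, is whether any group at this place moves the number beyond the scatter, for example a carboxylic acid, a primary amine or a longer chain. Also open, from the compounds shown here alone, is how the other stereoisomer of 3-hydroxypyrrolidin-1-yl would read.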